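Swapping the Aryl Group on a Thiosemicarbazone

This account rests on a few compounds, and the source may have more. Where it says the series, first, only, none or still open, it means among the compounds named here.

The shared core first appears as compound 1 `CC1=CC[C@H](C(C)(C)N=C=S)CC1`, which in a functional assay on PC-3 cells (Homo sapiens) for inhibition, read by sulforhodamine B assay, with a stated time of 48 h (a lower number here means a stronger inhibitor of growth, a higher number a weaker inhibitor of growth), gives only a limit, > 100000 nM. Compound 2 `CC1=CC[C@H](C(C)(C)NC(=S)NN)CC1` likewise gives only a limit in this assay, > 100000 nM. The step that the two limits leave unreadable from compound 1 to compound 2 therefore has no readable size, because both of its ends sit at the limit of > 100000 nM in this assay, at which 2 of the 3 values shown sit.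

Going by the values given here, compound 3 `COc1ccc(/C=N/NC(=S)NC(C)(C)[C@H]2CC=C(C)CC2)cc1` is the one compound with a number: in this assay compound 3 gives 1200 nM. Among the three values shown, it is the only number, and the other two are limits, so compound 3 stands alone and cannot be ranked against them.

Compound 4 `CC1=CC[C@H](C(C)(C)NC(=S)N/N=C/c2ccccc2Cl)CC1` differs from compound 3 in one place: 2-chlorophenyl in place of 4-methoxyphenyl on a carbon with a double bond to nitrogen. Among the compounds with values here, no measured step touches this position. Within the data shown here, the single step that was measured concerns a different part of the molecule and has no readable size, so it gives no guide to the direction or the size of the change at the carbon bearing the aryl group. With nothing to point either way, the expectation for compound 4 is a step that stays within the usual scatter, that is a 1.3-fold higher number from compound 3 to compound 4 (0.10 log units; within the scatter) relative to compound 3. On that basis compound 4 is estimated at 1500 nM in this assay, with a range from 500 nM to 5000 nM.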

Compound 4, concentration for total growth inhibition: 700 nM
Estimate against measurement, compound 4: 2.1-fold (0.33 log units) above; measured number inside the range.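

At the carbon with a double bond to nitrogen, there is now a first readable step: in this assay, 2-chlorophenyl in place of 4-methoxyphenyl gives a 1.7-fold lower number from compound 3 to compound 4 (0.23 log units; within the scatter). The oxygen of 4-methoxyphenyl leaves and the chlorine of 2-chlorophenyl enters, yet compound 3 and compound 4 cannot be told apart in this read-out, so this exchange of one aryl group for another shows no effect that can be separated from the scatter. Until this point the only step shown could not be read, since both of its ends are limits and not numbers: the limit of > 100000 nM in this assay, at which 2 of the 4 values shown sit.

Going by these compounds, with only these two aryl groups at this position, it remains open whether a plain phenyl, or an aryl group carrying an amine or a carboxylic acid, would also stay within the scatter or would move the value beyond it. Also open, on these data alone, is how a longer chain in place of the methoxy group, or any change to the shared core itself, would read in this assay.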